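The source may report more compounds than this note shows. Statements on the series, on what has been measured and on what is new or still open speak of the compounds shown alone.

Among the compounds with values here, in a functional assay on HL-60 cells (Homo sapiens) for inhibition, read by MTT assay, with a stated time of 72 h (on this read-out lower numbers stand for stronger inhibition and higher numbers for weaker inhibition), compound 1 `Cc1nc(-c2ccccc2)c(C(=O)N2CCN(c3cccc(Cl)c3Cl)CC2)o1` gives 133 nM, the highest of the two numbers measured so far. Compound 2 `Cc1nc(-c2ccc(F)cc2)c(C(=O)N2CCN(c3cc(Cl)cc(Cl)c3)CC2)o1` gives 52.1 nM in this assay, a lower number that lies beyond the usual scatter. Compound 3 `COc1cccc(N2CCN(C(=O)c3oc(C)nc3-c3ccccc3)CC2)c1` has not yet been measured. It differs from compound 1 by 3-methoxyphenyl in place of 2,3-dichlorophenyl on an amine nitrogen in a ring. Within the data shown here, no measured pair isolates this change, so its effect is uncertain. The step of a 2.3-fold higher number from compound 1 to compound 3 (0.35 log units; beyond the scatter) is expected, pointing toward weaker inhibition, though it may still fall within the scatter. Compound 3 is therefore expected to give 300 nM, within a range from 80 nM to 1200 nM in this assay.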

Compound 3, half-maximal inhibitory concentration: 34.8 nM
Beside the measured number, compound 3's estimate is 8.6-fold (0.94 log units) above it, outside the stated range (below it).
By their numbers in this assay, from the lowest: compounds 3 and 2 (each within the scatter of the next); then compound 1.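

In this assay, within the data shown here, the swap on the amine nitrogen in the ring gives a 3.8-fold lower number from compound 1 to compound 3 (0.58 log units; beyond the scatter), the first single-place comparison. It shows that 2,3-dichlorophenyl is not needed here for inhibition, since 3-methoxyphenyl gives the stronger result with the same count of heavy atoms. No measurement available here explains this gain. This single step cannot separate the effect of removing the two chlorines from that of adding the methoxy group. Going by these compounds, how a phenyl group carrying an amine or a carboxylic acid would behave here also remains open.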